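A few compounds are considered here, and "the series" means these few. Any claim that something is new, unique, unknown or untested is made for them only; others in the source may bear on it.

In an ADME assay on microsomes from liver (Mus musculus) for metabolic stability (a higher number here means that the compound lasts longer, a lower number that the compound disappears faster), compound 1 `O=C(O)c1ccc(N2CCC3(C=C(c4c(-c5c(Cl)cccc5Cl)noc4C4CC4)C3)CC2)nc1` gives 1.72 h and compound 3 `O=C(O)c1cc(F)c2nc(N3CCC(/C=C/c4c(-c5c(Cl)cccc5Cl)noc4C4CC4)CC3)sc2c1` gives 0.25 h as its half-life. These two compounds differ in more than one place, so their values say little about any single group. Compound 2 `O=C(O)c1cc(F)c2nc(N3CCC4(C=C(c5c(-c6ccccc6C(F)(F)F)noc5C5CC5)C4)CC3)sc2c1` reads > 2 h and that is a limit of the assay, not a number. Compound 2 stands at the limit of > 2 h in this assay, at which 1 of the 3 values shown sits, and no exact figure exists for it.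

Compound 4 `O=C(O)c1cc(F)c2nc(N3CCC4(C=C(c5c(-c6ccccc6OC(F)(F)F)noc5C5CC5)C4)CC3)sc2c1` is compound 2 with one group swapped. The change trifluoromethoxy in place of trifluoromethyl on an aromatic carbon puts trifluoromethoxy in place of trifluoromethyl on an aromatic carbon of a six-membered aromatic ring of carbon only, ortho to a large group. Within the data shown here, no measured pair shows this swap, so in this assay the expected step is none beyond the scatter, with no favoured direction. The estimated step that the limit leaves unreadable from compound 2 to compound 4 is therefore small. For compound 4 the estimate is 2.2 h with an expected range from 1.1 h to 4 h and the result may again be only a limit.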

Compound 4, half-life: 1.52 h
Estimate against measurement, compound 4: 1.4-fold (0.16 log units) above, within the range that was stated.
By their numbers in this assay, from the lowest: compound 3; then compounds 4 and 1 (each within the scatter of the next). At a limit, above all of these: compound 2.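

Among these compounds, this is the first comparison in the set that changes only one place. Putting trifluoromethoxy in place of trifluoromethyl on an aromatic carbon, ortho to a large group, gives in this assay an at least 1.3-fold lower number from compound 2 to compound 4 (0.11 log units; that floor lies within the scatter). The starting point of this step is a limit and not a number, so its true size cannot be read and only its floor is known: the limit of > 2 h in this assay, at which 1 of the 4 values shown sits.

The compounds shown leave open whether the real step lies beyond the scatter, and an exact reading for compound 2 would be needed to settle this. They also leave open how a methyl group, a methoxy group or a nitrile would read on the same aromatic carbon, and whether this swap would give a similar step on another core.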